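The source may hold more compounds than are shown below. What is called first, only, known or untested is meant among the compounds shown, and "the series" means these compounds.

Compound 1 `CCCCCCCCCCCCCCCCOP(=O)(O)OCCSC(=S)N1CCCCC1` is the starting point of this step. Among the measured compounds shown here, in a functional assay on MCF7 cells (Homo sapiens) for inhibition, read by MTT assay, with stated times of 18 h and 4 h (on this read-out lower numbers stand for stronger inhibition and higher numbers for weaker inhibition), compound 1 gives 29000 nM, the highest of the two numbers measured so far, though its nearest neighbour lies within the scatter. Compound 2 `CCCCCCCCOP(=O)(O)OCCSC(=S)N1CCCCC1` shares the same core; in this assay compound 2 gives 26000 nM. For the measured compounds named here, the single measured step, a 1.1-fold lower number from compound 1 to compound 2 (0.05 log units; within the scatter), leaves the piperidin-1-yl group untouched. Compound 3 `CCCCCCCCCCCCCCCCOP(=O)(O)OCCSC(=S)N1CCN(C)CC1` changes exactly that group: 4-methylpiperazin-1-yl in place of piperidin-1-yl on a thiocarbonyl carbon. Going by the values given here, no measured step bears on this part of the molecule, so nothing in the data sets a direction for the change. Among the compounds with values here, the only measured comparison stayed within the scatter, and with no evidence for movement either way, none beyond the scatter is expected here. Compound 3 is therefore expected to give about 30000 nM in this assay, within a range from 12000 nM to 75000 nM. This estimate means an expected step of a 1.0-fold higher number from compound 1 to compound 3 (0.01 log units; within the scatter), none beyond the scatter.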

Compound 3, half-maximal inhibitory concentration: > 100000 nM
Compound 3: no number, only a limit; the forecaster's own chance of this, stated with the estimate: 10%; middle value at least 3.3-fold (0.52 log units) away from the limit.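

Moving from piperidin-1-yl to 4-methylpiperazin-1-yl on a thiocarbonyl carbon gives an at least 3.4-fold higher number from compound 1 to compound 3 (0.53 log units; beyond the scatter) in this assay, so this position responds to a change, whereas the only earlier step, a 1.1-fold lower number from compound 1 to compound 2 (0.05 log units; within the scatter), was a change in the chain. The entering group differs from the one it replaces by a second ring nitrogen and a methyl group, and it counts one hydrogen-bond acceptor where piperidin-1-yl counts none, though nothing here shows which of these differences matters. The value of compound 3 is a limit of the assay and not a number: the limit of > 100000 nM in this assay, at which 1 of the 3 values shown sits.

Going by these compounds, it remains open whether the second ring nitrogen or its methyl group drives this step, which an unsubstituted piperazin-1-yl group or a morpholin-4-yl group could help to separate. On these data alone, it also remains open whether 4-methylpiperazin-1-yl would have the same effect on the shorter chain of compound 2.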